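The source may hold more compounds than are shown below. What is called first, only, known or untested is meant among the compounds shown, and "the series" means these compounds.

In an ADME assay on L1210/0 cells (Mus musculus) for cytotoxicity, with a stated time of 48 h (on this read-out higher numbers stand for weaker inhibition and lower numbers for stronger inhibition), compound 1 `O=c1[nH]c(=O)n([C@H]2C[C@H](O)[C@@H](CO)O2)cc1[N+](=O)[O-]` gives 130 nM as a true measured number. Compound 2 `CCCC#Cc1cn([C@H]2C[C@H](O)[C@@H](CO)O2)c(=O)[nH]c1=O` shows > 200000 nM, which is a limit of the assay and not a number. Compound 3 `CC#Cc1cn([C@H]2C[C@H](O)[C@@H](CO)O2)c(=O)[nH]c1=O` shows > 200000 nM, which is also a limit. Compound 3 therefore stands on (the limit of > 200000 nM in this assay, at which 2 of the 3 values shown sit), with no exact value to start from.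

Compound 4 `CCCc1cn([C@H]2C[C@H](O)[C@@H](CO)O2)c(=O)[nH]c1=O` differs from compound 3 by one group, with propyl in place of prop-1-yn-1-yl on an aromatic carbon.

Two large measured steps bear on this: an at least 1500-fold higher number from compound 1 to compound 2 (3.18 log units; beyond the scatter) and an at least 1500-fold higher number from compound 1 to compound 3 (3.18 log units; beyond the scatter). Both replace the nitro of compound 1 with a carbon chain, as compound 4 also does. Within the data shown here, the step that the two limits leave unreadable from compound 2 to compound 3 gives no size to work with, and no measured step swaps a triple-bonded chain for a saturated one. No step beyond the scatter is therefore expected in this assay, and a further limit is the likeliest result.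

The expected change is a number no higher from compound 3 to compound 4 (the limit leaves the size open). The estimate for compound 4 is 200000 nM, with an expected range from 60000 nM to 400000 nM.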

Compound 4, half-maximal inhibitory concentration: > 200000 nM
Compound 4: only a limit was reported (the forecaster's own chance of this, stated with the estimate: 75%); the middle value lies on the limit itself.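

In this assay compound 4 also gives only a limit, not a number, so a saturated propyl chain at this aromatic carbon does no better than the triple-bonded chains: the limit of > 200000 nM in this assay, at which 3 of the 4 values shown sit.

Removing the triple bond therefore does not, on its own, bring back a readable value. Against the nitro group of compound 1, the propyl chain gives an at least 1500-fold higher number from compound 1 to compound 4 (3.18 log units; beyond the scatter), so all three carbon chains shown now stand on the same side of that large gap.

The steps among compound 2, compound 3 and compound 4 cannot be read, so any differences among these chains remain hidden. As far as these compounds go, it also stays open whether a shorter chain such as ethyl, or a non-carbon group such as an amine or a nitrile, would give a true number closer to that of compound 1.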